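Swapping Ethylamino for Methylsulfanyl on a Bare Core

The source may hold more compounds than are shown below. What is called first, only, known or untested is meant among the compounds shown, and "the series" means these compounds.

Compound 1, `CSc1nccc2c1ncn2C1O[C@H](CO)[C@@H](O)[C@H]1O`: in a functional assay on EL4 cells (Mus musculus) for inhibition, tested at 100 uM (a lower number here means less inhibition, a higher number more inhibition at the concentration tested (going by the name of the read-out)), compound 1 gives < 5%, a limit of the assay rather than a number.
Compound 2, `CCNc1nccc2c1ncn2C1O[C@H](CO)[C@@H](O)[C@H]1O`: in this assay compound 2 gives 8%.
Compound 3, `CCNc1[nH]ccc2ncnc1-2`: in this assay compound 3 gives < 5%, again a limit of the assay.

Compounds 1 and 2 share one core, and compound 3 carries a smaller core; how the two cores differ is not broken down here.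

The change from compound 2 to compound 1 is methylsulfanyl in place of ethylamino on an aromatic carbon. It made a number at least 3 percentage points lower from compound 2 to compound 1 (that floor lies within the scatter). Both values are low, and the step between them does not leave the usual scatter.

The not yet measured compound 4, `CSc1[nH]ccc2ncnc1-2`, arises from compound 3 by the same change at the same place: methylsulfanyl in place of ethylamino on an aromatic carbon.

Going by the values given here, two of the three values sit at the limit of < 5% in this assay, at which 2 of the 3 values shown sit, and the one measured step of this change is small. Compound 3 rests at < 5%, a limit of the assay. The step expected from compound 3 to compound 4 is therefore a step that the limit leaves unreadable from compound 3 to compound 4, essentially no movement. For compound 4 the estimate in this assay is 3%, with a range from 0% to 10%, and most likely the assay will again report only a limit for compound 4.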

Compound 4, a percentage reported as inhibition, at one concentration (the size of the read-out at that concentration, not a potency): < 5%
Compound 4: only a limit was reported; the forecaster's own chance of this, stated with the estimate: 70%; the middle value lies beyond the limit too.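

Compound 3 and compound 4 both rest at a limit of this assay, so no step between them can be read, and the swap of ethylamino for methylsulfanyl has no readable size on this smaller core: the limit of < 5% in this assay, at which 3 of the 4 values shown sit.

The compounds shown leave open whether this swap changes inhibition on the smaller core at all, and in which direction.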